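Series notes: from compound 3 toward compound 4

A few compounds are considered here, and "the series" means these few. Any claim that something is new, unique, unknown or untested is made for them only; others in the source may bear on it.

Measured so far:
- compound 1 `CN(C)CCn1cnnc1-c1cc(Oc2ccc(NC(=O)N/N=C/c3c[nH]c4ccccc34)cc2F)ccn1`: 790 nM
- compound 2 `CN(C)CCn1cnnc1-c1cc(Oc2ccc(NC(=O)N/N=C/c3cc(C(C)(C)C)cc(C(C)(C)C)c3O)cc2F)ccn1`: 3300 nM
- compound 3 `COc1ccc(OC)c(/C=N/NC(=O)Nc2ccc(Oc3ccnc(-c4nncn4CCN(C)C)c3)c(F)c2)c1`: 1510 nM

All three numbers come from a functional assay on MKN-45 cells (Homo sapiens) for cytotoxicity, read by MTT assay, with a stated time of 72 h; a higher number here means a weaker inhibitor, a lower number a stronger inhibitor. Compound 3 stands second highest of the three: compound 1 sits nearest, the step of a 1.9-fold higher number from compound 1 to compound 3 (0.28 log units; within the scatter) lying within the scatter, while compound 2 gives the higher number of the set, its value and that of compound 3 being separated by a gap beyond the scatter.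

Compound 4 `CN(C)CCn1cnnc1-c1cc(Oc2ccc(NC(=O)N/N=C/c3ccc(O)c(Br)c3)cc2F)ccn1` is not yet measured. It differs from compound 3 in one place: 3-bromo-4-hydroxyphenyl in place of 2,5-dimethoxyphenyl on a carbon with a double bond to nitrogen. Among the measured compounds shown here, the only measured step at this same position is a 1.9-fold higher number from compound 1 to compound 3 (0.28 log units; within the scatter), which was within the scatter. Compound 2 carries a hydroxyl-bearing ring at the same place and gives the highest number, but it is not a single-place neighbour of compound 3, so it is only a loose pointer. The expectation for this assay is therefore no step beyond the scatter, expressed as a 1.2-fold lower number from compound 3 to compound 4 (0.07 log units; within the scatter). Compound 4 is estimated at 1300 nM, with a range from 400 nM to 4500 nM.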

Compound 4, half-maximal inhibitory concentration: 1860 nM
Beside the measured number, compound 4's estimate is 1.4-fold (0.16 log units) below it; the measured number falls inside the stated range.
By their numbers in this assay, from the lowest: compounds 1, 3, 4 and 2 (each within the scatter of the next, the first and the last beyond it).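

In this assay, putting 3-bromo-4-hydroxyphenyl in place of 2,5-dimethoxyphenyl on the carbon with a double bond to nitrogen gives a 1.2-fold higher number from compound 3 to compound 4 (0.09 log units; within the scatter) and so separates compound 3 and compound 4 by no more than the usual spread, although the two rings share neither their substituents nor their donor count. Measured against 1H-indol-3-yl, the same ring gives a 2.4-fold higher number from compound 1 to compound 4 (0.37 log units; beyond the scatter) and clears the scatter, modestly, where a 1.9-fold higher number from compound 1 to compound 3 (0.28 log units; within the scatter) does not. No supporting measurement accompanies these cell values, so the numbers offer no explanation for either step.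

The bromine and the hydroxyl enter together in compound 4, so the compounds shown cannot assign the step from compound 1 to either one. Also open, as far as these compounds go, is how this position responds to a ring carrying a carboxylic acid or a nitrile.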